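A few compounds are considered here, and "the series" means these few. Any claim that something is new, unique, unknown or untested is made for them only; others in the source may bear on it.

Measured compounds in an assay on isolated protein for inhibition of alpha-mannosidase (Canavalia ensiformis), read by spectrophotometry, tested at 1000 uM; on this read-out higher numbers stand for more inhibition at the one concentration tested (going by the name of the read-out) and lower numbers for less inhibition:

Compound 1 `O[C@@H]1[C@@H](O)CN[C@H]1c1ccccc1` gives 2%.
Compound 2 `O[C@@H]1[C@@H](O)CN[C@H]1c1ccc(F)cc1` gives 1.2%.
Compound 3 `O[C@H]1[C@H](O)CN[C@@H]1c1ccc(F)cc1` gives 0.8%.

All three measured compounds sit close to the bottom of the read-out in this assay . Compound 2 and compound 3 share every atom and bond and differ only in how their configuration is drawn (the two compounds have the same atoms and bonds and differ only in configuration as drawn: 3 of 3 stereo elements differ (all stereocentres are inverted: mirror images); a stereocentre at a saturated ring carbon is drawn S in compound 2 and R in compound 3; a stereocentre at a saturated ring carbon is drawn S in compound 2 and R in compound 3; a stereocentre at a saturated ring carbon is drawn S in compound 2 and R in compound 3); that this is the sole difference between the two cores is what the structures show (the fact that compounds 2 and 3 differ only in the configuration as drawn). In this assay the step is a number 0.4 percentage points lower from compound 2 to compound 3 (within the scatter), so the two mirror images cannot be told apart here.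

Compound 4 `O[C@H]1[C@H](O)CN[C@@H]1c1ccccc1` is not yet measured. It stands to compound 3 as compound 1 stands to compound 2: hydrogen in place of fluoro on an aromatic carbon, and the change made between the two measured compounds is the same one (hydrogen in place of fluoro on an aromatic carbon). Among the compounds shown this change occurs twice in all. For the measured compounds named here, its one measured instance gave a number 0.8 percentage points higher from compound 2 to compound 1 (within the scatter), a step that does not leave the scatter.

On that basis the step from compound 3 to compound 4 is expected to be small as well, near a number 0.7 percentage points higher from compound 3 to compound 4 (within the scatter), resting on the measured step of a number 0.8 percentage points higher from compound 2 to compound 1 (within the scatter) and on the low value of compound 3, 0.8%. Compound 4 is therefore estimated at 1.5%, with an expected range from 0% to 5%.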

Compound 4, a percentage reported as inhibition, at one concentration (the size of the read-out at that concentration, not a potency): 8.3%
Beside the measured number, compound 4's estimate is 6.8 percentage points below it, and the stated range ends below it.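

On the mirror-image core, hydrogen in place of fluoro on an aromatic carbon gives a number 7.5 percentage points higher from compound 3 to compound 4 (within the scatter) in this assay, and set beside the same change on the other core, the two steps cannot be told apart: the same change on two cores in this assay, a number 0.8 percentage points higher (within the scatter) from compound 2 to compound 1 and a number 7.5 percentage points higher (within the scatter) from compound 3 to compound 4, 6.7 percentage points apart, within the scatter of two such steps. The inversion of all stereocentres in the pair without fluoro, a number 6.3 percentage points higher from compound 1 to compound 4 (within the scatter), also stays inside the scatter, so the mirror images cannot be told apart in this pair either: the fact that compounds 1 and 4 differ only in the configuration as drawn. The change therefore carries from one core to the other without a difference that this assay can resolve, but this does not show that the two steps are equal in size or that the change has no effect on either core, and two instances set no rule for the series.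

The compounds shown leave open whether another group on that aromatic carbon, such as chloro, methoxy, an amine or a carboxylic acid, would give a step beyond the scatter on either core. They also leave open how these compounds would compare at any other concentration, as all the readings here come from a single concentration.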